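Adding a Second Chloro to a Curcumin-Type Cyclohexanone

The source may hold more compounds than are shown below. What is called first, only, known or untested is meant among the compounds shown, and "the series" means these compounds.

Of the compounds shown here, two have been measured in a functional assay on SW-620 cells (Homo sapiens) for cytotoxicity, read by MTT assay, with a stated time of 72 h; on this read-out higher numbers stand for weaker inhibition and lower numbers for stronger inhibition. Compound 1 `COc1cccc(/C=C2\CCC/C(=C\c3cc(Cl)cc(Cl)c3)C2=O)c1OC` gives 5500 nM in this assay, and compound 2 `COc1ccc(/C=C2\CCC/C(=C\c3ccccc3Cl)C2=O)cc1OC` gives 7100 nM. Compound 2 has the highest of the two numbers, but its nearest neighbour is compound 1, and the gap between the two lies within the scatter, so the two values show no difference that can be read as an order.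

Compound 3 `COc1ccc(/C=C2\CCC/C(=C\c3cccc(Cl)c3Cl)C2=O)cc1OC` has not yet been measured. It differs from compound 2 in one place: chloro in place of hydrogen on an aromatic carbon. The group that enters is chloro, a single chlorine, sitting on an aromatic carbon of a six-membered aromatic ring of carbon only, ortho to a chloro group and meta to a large group; cut one bond further out, the change reads 2-chlorophenyl to 2,3-dichlorophenyl.

Among the measured compounds shown here, no measured pair in this set shows the effect of such a change, so the expectation rests on compound 2 alone. The step from compound 2 to compound 3 in this assay is expected to be small, a 1.3-fold lower number from compound 2 to compound 3 (0.11 log units; within the scatter), with no clear direction beyond the scatter. Compound 3 is therefore estimated at 5500 nM, with a range from 2200 nM to 14000 nM.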

Compound 3, half-maximal inhibitory concentration: 10800 nM
Beside the measured number, compound 3's estimate is 2.0-fold (0.29 log units) below it; measured number inside the range.
By their numbers in this assay, from the lowest: compounds 1, 2 and 3 (each within the scatter of the next).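

Among the compounds shown here, the change from 2-chlorophenyl to 2,3-dichlorophenyl is the first single-place step, and in this assay it reads as a 1.5-fold higher number from compound 2 to compound 3 (0.18 log units; within the scatter). It shows that a chloro can take the place of hydrogen on this aromatic carbon, ortho to a chloro group and meta to a large group, without a difference that can be told from the scatter, so this one change gives no direction for this position. Nothing measured here bears on what lies behind the step, and no explanation can be offered for it.

The compounds shown leave open whether this aromatic carbon would read the same way with a group of a different kind in place of the chloro, such as an amine or a carboxylic acid. They also leave open whether the same chloro step would read alike with a hydroxyl in place of a methoxy on the other aromatic ring of the shared core.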